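A Chlorine Added to the Phenoxy Ring

The source may report more compounds than this note shows. Statements on the series, on what has been measured and on what is new or still open speak of the compounds shown alone.

Of the compounds shown here, three that share one core have been measured in an in vitro assay on SH-EP1 cells for displacement of a labelled ligand from Neuronal acetylcholine receptor; alpha4/beta2 (Homo sapiens); on this read-out higher numbers stand for weaker inhibition and lower numbers for stronger inhibition. Compound 1 `C1=C(c2cncc(OCc3ccccc3)c2)CC2CNCC1C2` gives 0.7 nM. Compound 2 `C1=C(c2cncc(Oc3ccccc3)c2)CC2CNCC1C2` gives 0.7 nM, and compound 3 `FC(F)(F)c1cncc(C2=CC3CNCC(C2)C3)c1` gives 0.7 nM. Compound 2 thus stands level with compound 1 and compound 3 at these digits: the step of no change at the digits printed from compound 1 to compound 2 (within the scatter) and the step of no change at the digits printed from compound 2 to compound 3 (within the scatter) are both within the scatter, even though the first swaps phenyl for benzyl on an oxygen and the second swaps trifluoromethyl for phenoxy on an aromatic carbon.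

Compound 4 `Clc1cccc(Oc2cncc(C3=CC4CNCC(C3)C4)c2)c1` has not been measured. It differs from compound 2 by chloro in place of hydrogen on an aromatic carbon, on an aromatic carbon of a six-membered aromatic ring of carbon only, meta to a large group; cut one bond further out, phenyl becomes 3-chlorophenyl. The two measured steps bear on this change only loosely, since neither touches the chlorine position, but both show that sizeable alterations in this region of the molecule left this assay unchanged. A small chloro addition is therefore expected to give no step beyond the scatter, so the estimated step is no change at the digits printed from compound 2 to compound 4 (within the scatter). Compound 4 is expected to give about 0.7 nM in this assay, with a range from 0.35 nM to 1.4 nM.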

Compound 4, inhibition constant: 1 nM
Compound 4: the middle estimate sits 1.4-fold (0.15 log units) below what was measured; measured number inside the range.
By their numbers in this assay, from the lowest: compounds 1, 2, 3 and 4 (each within the scatter of the next).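

Chloro in place of hydrogen on an aromatic carbon of the outer ring, meta to a large group, gives a 1.4-fold higher number from compound 2 to compound 4 (0.15 log units; within the scatter) in this assay. This is the first change shown on that outer ring itself, and a single chlorine atom at this place leaves the read-out within the scatter, as does the wider exchange of 3-chlorophenyl in place of benzyl on the oxygen, which gives a 1.4-fold higher number from compound 1 to compound 4 (0.15 log units; within the scatter) and so adds a second comparison that cannot separate the two compounds. Nothing at hand speaks to the reason the number stays so flat across these changes.

From the compounds shown here alone, whether an amine, a carboxylic acid or a methoxy group on this same aromatic carbon would also stay within the scatter remains open, and a group of that kind would test this place far harder than one chlorine atom does. Also open, going by these compounds, is whether chloro on the other carbons of that ring would behave as it does here, and whether the same flat picture would hold on any receptor other than the one tested.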